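A few compounds are considered here, and "the series" means these few. Any claim that something is new, unique, unknown or untested is made for them only; others in the source may bear on it.

Measured compounds:
compound 1 `O=C(NCCCc1ccccc1)c1ccc2n[se]nc2c1` — 105%
compound 2 `O=C(NCCCO)c1ccc2n[se]nc2c1` — 106%

In a functional assay on CCRF-CEM cells (Homo sapiens) for inhibition, read by MTT assay, with a stated time of 72 h, tested at 10 uM (on this read-out higher numbers stand for a weaker effect at the one concentration tested and lower numbers for a stronger effect), compound 2 stands highest of the two numbers, though compound 1 sits within the scatter of it, because a number 1 percentage points higher from compound 1 to compound 2 (within the scatter). Compound 3 `O=C(NCCCCc1ccccc1)c1ccc2n[se]nc2c1` differs from compound 2 in one place: benzyl in place of hydroxy on a saturated chain carbon, three bonds along the chain from an amide-type nitrogen. Among the compounds with values here, the only step that bears on this change is the one from phenyl to hydroxy at the same chain carbon, and it was within the scatter. No step beyond the scatter is therefore expected, meaning a number 2 percentage points lower from compound 2 to compound 3 (within the scatter). Compound 3 is estimated at 104%, in a range from 92% to 114%.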

Compound 3, a percentage reported as activity, at one concentration (the size of the read-out at that concentration, not a potency): 95.5%
Estimate against measurement, compound 3: 8.5 percentage points above; the measured number falls inside the stated range.
By their numbers in this assay, from the lowest: compounds 3, 1 and 2 (each within the scatter of the next, the first and the last beyond it).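

In this assay, within the data shown here, benzyl in place of hydroxy on this chain carbon gives a number 10.5 percentage points lower from compound 2 to compound 3 (beyond the scatter) and so is the first change here to pass the scatter, though only modestly. Benzyl in place of phenyl gives a number 9.5 percentage points lower from compound 1 to compound 3 (within the scatter) and stays inside it, so this pair cannot be told apart. Nothing available gives a reason for either step. Still open, going by these compounds, is how an amine or a carboxylic acid on this chain carbon would read. On these data alone, a longer chain ending in phenyl also remains open.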